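This account rests on a few compounds, and the source may have more. Where it says the series, first, only, none or still open, it means among the compounds named here.

Of the compounds shown here, two of the shared core have been measured so far: compound 1 `COc1cccc(OC)c1C(=O)Nc1nnc(-c2ccc(C)cc2)s1` and compound 2 `COc1cccc(OC)c1C(=O)Nc1nnc(-c2ccc([N+](=O)[O-])cc2)s1`. In a physicochemical assay for lipophilicity, measured as octanol-water partition (a higher number here means a more lipophilic compound, a lower number a more polar compound), compound 1 gives 3.85, and compound 2 gives 2.54. Compound 1 thus stands highest of the two numbers. For the measured compounds named here, the only measured step, a number 1.31 log units lower from compound 1 to compound 2 (beyond the scatter), is a change of a different kind from the one considered next.

Compound 3 `CCOc1ccc(-c2nnc(NC(=O)c3c(OC)cccc3OC)s2)cc1` differs from compound 1 in one place: ethoxy in place of methyl on an aromatic carbon. Going by the values given here, no measured step covers an ethoxy group entering in place of methyl, so the step from compound 1 to compound 2 gives no direct guide beyond showing that a change at the same place can move this assay strongly. For ethoxy in place of methyl, the expectation is a step staying within the scatter, a number 0.15 log units lower from compound 1 to compound 3 (within the scatter). Compound 3 is therefore estimated at 3.7 in this assay, with a range from 3.35 to 4.05.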

Compound 3, partition coefficient: 3.75
The estimate for compound 3 lay 0.05 log units below the measured number; the range from low to high includes it.
By their numbers in this assay, from the lowest: compound 2; then compounds 3 and 1 (each within the scatter of the next).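

In this assay, ethoxy in place of methyl on this aromatic carbon, para to a large group, gives a number 0.10 log units lower from compound 1 to compound 3 (within the scatter) and so leaves compound 1 and compound 3 indistinguishable, although the entering group has more heavy atoms and a hydrogen-bond acceptor. Ethoxy in place of nitro gives a number 1.21 log units higher from compound 2 to compound 3 (beyond the scatter), so this position now shows that a change here can produce either a large step or none beyond the scatter. Nothing measured on these compounds accounts for the difference between the two steps.

With only methyl, ethoxy and nitro shown at this position, it remains open whether the large step is particular to nitro. Where an amine, a carboxylic acid or a longer alkoxy chain would fall in this assay also remains open.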